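This account rests on a few compounds, and the source may have more. Where it says the series, first, only, none or still open, it means among the compounds named here.

Measured so far:
compound 1, `CCN1CCN(c2nc(NCc3ccc(F)cc3)nc3c2ncn3CCCN2CCCC2)CC1` — 40 nM
compound 2, `CCN1CCN(CCCn2cnc3c(N4CCN(C(=O)C5CCCC5)CC4)nc(NCc4ccc(OC)cc4)nc32)CC1` — > 30000 nM
compound 3, `CCN1CCN(CCCn2cnc3c(N4CCN(C5CCCC5)CC4)nc(NC(=O)c4ccc(CN(C)C)cc4)nc32)CC1` — 60 nM

In an assay on HEK293 cells for antagonist activity at Toll-like receptor 9 (Homo sapiens), read by spectrophotometry (on this read-out higher numbers stand for weaker inhibition and lower numbers for stronger inhibition), compound 1 gives 40 nM and compound 3 gives 60 nM. Compound 2 reaches only the limit of this assay, > 30000 nM, a limit and not a number. For the measured compounds named here, it is the single value at the limit of > 30000 nM in this assay, at which 1 of the 3 values shown sits, so compound 2 stands at the weak end of the three without a number of its own. Compound 4, `CCN1CCN(CCCn2cnc3c(N4CCN(CC)CC4)nc(NCc4ccc(OC)cc4)nc32)CC1`, is not yet measured; it differs from compound 2 by ethyl in place of cyclopentylcarbonyl on an amine nitrogen in a ring. Going by the values given here, no measured pair shows this change on its own. Compound 1 carries an ethyl on an amine nitrogen in a ring, as compound 4 does, so a large step toward stronger inhibition is expected, about an at least 300-fold lower number from compound 2 to compound 4 (2.47 log units; beyond the scatter). Compound 4 is expected near 100 nM, between 20 nM and 1000 nM, because compound 1 gives 40 nM.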

Compound 4, half-maximal inhibitory concentration: 200 nM
Estimate against measurement, compound 4: 2.0-fold (0.30 log units) below, and the stated range covers the measured number.
By their numbers in this assay, from the lowest: compounds 1 and 3 (each within the scatter of the next); then compound 4. At a limit, above all of these: compound 2.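

In this assay, ethyl in place of cyclopentylcarbonyl on an amine nitrogen in a ring gives an at least 150-fold lower number from compound 2 to compound 4 (2.17 log units; beyond the scatter), the only one-place read at this position. The group on this nitrogen alone separates a measurable value from the end of the assay's range. The size of the step has only a lower bound, as compound 2 stands at a limit and not at a number: the limit of > 30000 nM in this assay, at which 1 of the 4 values shown sits.

Whether the carbonyl or the five-membered ring of the leaving group accounts for the step stays open. So does the outcome with an acetyl or a butyl on this nitrogen.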